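The compounds below may be only part of what the source reports. "The series", "measured", "known", "first", "only" and "open" are said of these compounds alone.

Measured so far in an ADME assay on L1210/0 cells (Mus musculus) for cytotoxicity, with a stated time of 48 h; a higher number here means a weaker inhibitor, a lower number a stronger inhibitor:
- Compound 1 `COc1ncnc2c1ncn2C[C@@H]1C[C@H](O)c2ccccc21`: > 200000 nM (a limit)
- Compound 2 `CC1=C(C)C(=O)C(c2cn([C@H]3C[C@H](O)[C@@H](CO)O3)c(=O)[nH]c2=O)=CC1=O`: 112000 nM
- Compound 3 `CCOC(=O)COCn1cc(/C=C/Br)c(=O)[nH]c1=O`: > 200000 nM (a limit)

Compound 3 stands at > 200000 nM, which is a limit of the assay and not a number. It is not alone there, as the series shows (the limit of > 200000 nM in this assay, at which 2 of the 3 values shown sit). Compound 2 is the only one of the three with a number, at 112000 nM.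

The next compound to be measured is compound 4 `O=c1[nH]c(=O)n(COCCO)cc1/C=C/Br`. It differs from compound 3 in one place: hydroxymethyl in place of ethoxycarbonyl on a saturated chain carbon bound to an oxygen on a saturated carbon. In plain terms, hydroxymethyl takes the place of ethoxycarbonyl on a saturated chain carbon bound to an oxygen on a saturated carbon, so that (ethoxycarbonyl)methyl becomes 2-hydroxyethyl.

Among the compounds with values here, no measured step shows what such a change does. In this assay, therefore, a step no larger than the usual scatter is expected, with no firm direction, and compound 4 may well be reported as a limit again. The estimated step of an at least 1.1-fold lower number from compound 3 to compound 4 (0.07 log units; that floor lies within the scatter) is expected to be small on that basis. For compound 4 the estimate is 170000 nM, with an expected range from 60000 nM to 400000 nM.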

Compound 4, half-maximal inhibitory concentration: > 200000 nM
Compound 4 gave a limit, no number; the forecaster's own chance of this, stated with the estimate: 55%; middle value at least 1.1-fold (0.07 log units) away from the limit.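

In this assay compound 4 gives > 200000 nM, a limit of the assay and not a number. Compound 3 also sits at a limit, so no step can be read between compound 3 and compound 4: the limit of > 200000 nM in this assay, at which 3 of the 4 values shown sit. The compounds shown leave open what hydroxymethyl in place of ethoxycarbonyl does to the read-out.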